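Three Measured Compounds and One Expected Value

The source may report more compounds than this note shows. Statements on the series, on what has been measured and on what is new or still open speak of the compounds shown alone.

Measured in a functional assay on MGC-803 cells (Homo sapiens) for antiproliferative activity, read by CCK-8 assay, with a stated time of 72 h, tested at 2 uM; a lower number here means a weaker effect, a higher number a stronger effect of the compound at the concentration tested:
compound 1 `Nc1ccccc1NC(=O)c1ccc(CSC(=S)N2CCN(Cc3ccccn3)CC2)cc1`: 23.4%
compound 2 `Nc1ccccc1NC(=O)c1ccc(CSC(=S)N2CCN(C(c3ccccc3)c3ccccc3)CC2)cc1`: 9.8%
compound 3 `Nc1ccccc1NC(=O)c1ccc(CSC(=S)N2CCCc3ccccc32)cc1`: 38.5%

Of these three numbers compound 3 stands highest. Compound 1 comes nearest to it, with a number lower by a margin beyond the scatter, and compound 2 lies furthest away, lower still and also beyond the scatter.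

Compound 4 `CN1CCN(C(=S)SCc2ccc(C(=O)Nc3ccccc3N)cc2)CC1` has not yet been measured. It differs from compound 3 in one place: 4-methylpiperazin-1-yl in place of 1,2,3,4-tetrahydroquinolin-1-yl on a thiocarbonyl carbon. Among the measured compounds shown here, no pair of measured compounds differs in exactly one place, so no measured step can be read off to guide the expectation directly. What the numbers do show is that both compounds carrying another group than compound 3 on the thiocarbonyl carbon give lower readings in this assay.

On that basis a downward step is expected for compound 4, of the size a number 18.5 percentage points lower from compound 3 to compound 4 (beyond the scatter). Compound 4 is therefore estimated at 20%, with an expected range from 5% to 35%.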

Compound 4, a percentage reported as inhibition, at one concentration (the size of the read-out at that concentration, not a potency): 29.6%
Estimate against measurement, compound 4: 9.6 percentage points below, and the stated range covers the measured number.
By their numbers in this assay, from the lowest: compound 2; then compounds 1, 4 and 3 (each within the scatter of the next, the first and the last beyond it).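

In this assay, 4-methylpiperazin-1-yl in place of 1,2,3,4-tetrahydroquinolin-1-yl on the thiocarbonyl carbon gives a number 8.9 percentage points lower from compound 3 to compound 4 (within the scatter), so this first one-place exchange at the position, which removes the six-membered aromatic ring of carbon only, cannot be told from no change. The second step, hydrogen in place of pyridin-2-yl on a saturated chain carbon bound to an amine nitrogen in a ring, gives a number 6.2 percentage points higher from compound 1 to compound 4 (within the scatter), so the pyridin-2-yl group also leaves the reading indistinguishable within the scatter. Nothing available gives a reason for either step.

On these data alone, whether a morpholin-4-yl or piperidin-1-yl group on the thiocarbonyl carbon would read any differently from the 4-methylpiperazin-1-yl group remains open. So does the effect of an ethyl group or a longer chain in place of the methyl group of compound 4.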